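The source may report more compounds than this note shows. Statements on the series, on what has been measured and on what is new or still open speak of the compounds shown alone.

Measured so far:
Compound 1 `Cc1oc2ccc(NC(=O)COc3ccc(OC(F)(F)F)cc3)cc2c1C`: in an assay on CHO cells for displacement of a labelled ligand from melanin-concentrating hormone receptor 1 (Homo sapiens), read by scintillation counting, with a stated time of 1 h (a lower number here means a stronger inhibitor, a higher number a weaker inhibitor), compound 1 gives > 1000 nM, which is a limit of the assay and not a number.
Compound 2 `Cc1c(C2CC2)nc2ccc(-n3ccc(OCc4ccccc4)cc3=O)cn12`: in this assay compound 2 gives 42 nM.
Compound 3 `Cc1c(C2CC2)nc2ccc(-n3ccc(OCc4ccc(F)cc4)cc3=O)cn12`: in this assay compound 3 gives 47 nM.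

Compound 3 holds the higher of the two numbers, with compound 2 nearest; the step of a 1.1-fold higher number from compound 2 to compound 3 (0.05 log units; within the scatter) lies within the scatter, so no order between the two is claimed. Compound 4 `Cc1c(C2CC2)nc2ccc(-n3ccc(OCc4ccc(Br)cc4)cc3=O)cn12` differs from compound 3 by bromo in place of fluoro on an aromatic carbon. Among the measured compounds shown here, the only measured step that bears on this is a 1.1-fold higher number from compound 2 to compound 3 (0.05 log units; within the scatter), likewise a change on an aromatic carbon of that ring, which left the number unchanged beyond the scatter. On that basis no step beyond the scatter is expected, a 1.1-fold higher number from compound 3 to compound 4 (0.03 log units; within the scatter). Compound 4 is estimated at 50 nM in this assay, within 20 nM to 130 nM.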

Compound 4, half-maximal inhibitory concentration: 12 nM
Beside the measured number, compound 4's estimate is 4.2-fold (0.62 log units) above it; the whole stated range lies above it.
By their numbers in this assay, from the lowest: compound 4; then compounds 2 and 3 (each within the scatter of the next). At a limit, above all of these: compound 1.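

On the aromatic carbon para to a large group, the substituent does matter in this assay: the earlier hydrogen-to-fluoro change gave only a 1.1-fold higher number from compound 2 to compound 3 (0.05 log units; within the scatter), whereas bromo gives a 3.9-fold lower number from compound 3 to compound 4 (0.59 log units; beyond the scatter) and a 3.5-fold lower number from compound 2 to compound 4 (0.54 log units; beyond the scatter). Bromo is thus the only group shown here that moves the number beyond the scatter, whether it replaces fluoro or hydrogen. Nothing shown accounts for this difference.

Going by these compounds, whether chloro, methyl, methoxy or a nitrile at this place would follow bromo or fluoro stays open. So does whether iodo would take the number lower still.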